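The compounds below may be only part of what the source reports. "The series", "measured", "known", "first", "only" and "open" are said of these compounds alone.

Measured so far:
- compound 1, `CCO/N=C(/c1ccc(Br)cc1)C1CCN(C(C)(C)CCNC(=O)c2c(Cl)cncc2Cl)CC1`, gives 34000 nM in an ADME assay on PBMC cells (Homo sapiens) for cytotoxicity; on this read-out lower numbers stand for higher toxicity in this test and higher numbers for lower toxicity in this test.
- compound 2, `Cc1cccc(OC(c2ccc(Br)cc2)C2CCN(C(C)CCNC(=O)c3c(Cl)cncc3Cl)CC2)n1`, gives 6500 nM in this assay.
- compound 3, `CC(CCNC(=O)c1c(Cl)cncc1Cl)N1CCC(C(Oc2cccc(C(=O)O)n2)c2ccc(C(F)(F)F)cc2)CC1`, gives 28700 nM in this assay.

Among these three numbers compound 3 stands second highest. Its value and that of compound 1 lie within the usual scatter of each other, so nothing separates them. Compound 2 lies beyond the scatter, with the lower number of the set, meaning it is the more toxic of the pair when set against compound 3.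

Compound 4, `CC(CCNC(=O)c1c(Cl)cncc1Cl)N1CCC(C(Oc2ccccc2C#N)c2ccc(C(F)(F)F)cc2)CC1`, has not yet been measured in this assay. It differs from compound 3 in one place: 2-cyanophenyl in place of 6-carboxypyridin-2-yl on an oxygen on a saturated carbon. The group that leaves carries a carboxylic acid on a pyridine ring; the group that enters carries a nitrile on a ring of carbon only. For the measured compounds named here, no measured pair shows this change directly, so its size is unknown.

Compound 4 is expected to give a somewhat lower number than compound 3, a step of a 1.9-fold lower number from compound 3 to compound 4 (0.28 log units; within the scatter), only modestly beyond the scatter. The estimate for compound 4 is 15000 nM, with a range from 5000 nM to 40000 nM.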

Compound 4, half-maximal cytotoxic concentration: 17000 nM
Estimate against measurement, compound 4: 1.1-fold (0.05 log units) below; low and high end bracket the measured number.
By their numbers in this assay, from the lowest: compound 2; then compounds 4, 3 and 1 (each within the scatter of the next).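

In this assay, for the compounds shown here, putting 2-cyanophenyl in place of 6-carboxypyridin-2-yl on this oxygen gives a 1.7-fold lower number from compound 3 to compound 4 (0.23 log units; within the scatter), the first direct reading of a change at this position. This test therefore does not tell apart a carboxylic acid on a pyridine ring from a nitrile on a ring of carbon only, at least with the rest of the molecule held as in compound 3. Nothing measured here speaks to why the step is this small.

On these data alone, the ring and the group on it change together in this single pair, so the effect of each one alone remains open. A phenyl ring carrying a carboxylic acid, or a pyridine ring carrying a nitrile, would separate the two, and a bare phenyl ring would show what either group adds.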